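A few compounds are considered here, and "the series" means these few. Any claim that something is new, unique, unknown or untested is made for them only; others in the source may bear on it.

Working notes on the series

The shared core carries an anilide on one side and an arylamino group on the other. Compound 1 `CCC/C=C/C(=O)Nc1cccc(Oc2nc(Nc3cccc(C#N)c3)nc3c2CSCC3)c1` gives 7220 nM in a functional assay on HeLa cells (Homo sapiens) for antiproliferative activity, read by MTT assay, with a stated time of 72 h; a higher number here means a weaker inhibitor, a lower number a stronger inhibitor. Compound 2 `CC(C)=CC(=O)Nc1cccc(Oc2nc(Nc3cccc(C#N)c3)nc3c2CSCC3)c1` differs from compound 1 by 2-methylprop-1-en-1-yl in place of pent-1-en-1-yl on a carbonyl carbon. In this assay compound 2 gives 29200 nM, so the step of a 4.0-fold higher number from compound 1 to compound 2 (0.61 log units; beyond the scatter). Compound 3 `CCC/C=C/C(=O)Nc1cccc(Oc2nc(Nc3ccc(OC)nc3)nc3c2CSCC3)c1` differs from compound 1 on the other side of the core by 6-methoxypyridin-3-yl in place of 3-cyanophenyl on a nitrogen on an aromatic ring; in this assay compound 3 gives 15300 nM, a step of a 2.1-fold higher number from compound 1 to compound 3 (0.33 log units; beyond the scatter). The values of compound 2 and compound 3 lie within the scatter of each other.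

Compound 4 `COc1ccc(Nc2nc3c(c(Oc4cccc(NC(=O)C=C(C)C)c4)n2)CSCC3)cn1` has not yet been measured. It differs from compound 3 by 2-methylprop-1-en-1-yl in place of pent-1-en-1-yl on a carbonyl carbon, the same change that carries compound 1 to compound 2; the two "place" descriptions are identical, a carbonyl carbon whose other neighbours are an amide-type nitrogen. The two cores differ by 6-methoxypyridin-3-yl in place of 3-cyanophenyl on a nitrogen on an aromatic ring.

Among the compounds with values here, the one measured instance of this change gave a 4.0-fold higher number from compound 1 to compound 2 (0.61 log units; beyond the scatter). On the assumption that the change behaves alike on the core of compound 3, a step of about a 3.8-fold higher number from compound 3 to compound 4 (0.58 log units; beyond the scatter) in this assay is expected from compound 3 to compound 4. Within the data shown here, for compound 4 the estimate in this assay is therefore 58000 nM, with the spread 25000 nM to 140000 nM, resting on the single step of a 4.0-fold higher number from compound 1 to compound 2 (0.61 log units; beyond the scatter) and the value of compound 3, 15300 nM. Among the measured compounds shown here, only one example of the change exists, so the transfer is uncertain.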

Compound 4, half-maximal inhibitory concentration: 29200 nM
Compound 4: the middle estimate sits 2.0-fold (0.30 log units) above what was measured; the measured number falls inside the stated range.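

On the core of compound 3, 2-methylprop-1-en-1-yl in place of pent-1-en-1-yl gives a 1.9-fold higher number from compound 3 to compound 4 (0.28 log units; within the scatter) in this assay, and the two steps seen for this change cannot be told apart: the same change on two cores in this assay, a 4.0-fold higher number (0.61 log units; beyond the scatter) from compound 1 to compound 2 and a 1.9-fold higher number (0.28 log units; within the scatter) from compound 3 to compound 4, 2.1-fold (0.33 log units) apart, within the scatter of two such steps

With the other change, 6-methoxypyridin-3-yl in place of 3-cyanophenyl on a nitrogen on an aromatic ring gives no change at the digits printed from compound 2 to compound 4 (within the scatter), and this change likewise reads the same on both cores: the same change on two cores in this assay, a 2.1-fold higher number (0.33 log units; beyond the scatter) from compound 1 to compound 3 and no change at the digits printed (within the scatter) from compound 2 to compound 4, 2.1-fold (0.33 log units) apart, within the scatter of two such steps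

Within the data shown here, the four compounds therefore give no sign that either change depends on the core it is made on, but they do not show that the size of either change is fixed, since each change rests on only two steps and the gap between those steps is small enough to be lost in the scatter.

The compounds shown leave open how a longer chain, or an alkenyl group ending in a dimethylamino group, would read on the carbonyl carbon in this assay. Also open, from the compounds shown here alone, is whether the two changes would still carry over with an arylamino group bearing a carboxylic acid or a primary amine in place of 3-cyanophenyl or 6-methoxypyridin-3-yl.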